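Swapping isobutyl for sec-butyl on a sulfur

This account rests on a few compounds, and the source may have more. Where it says the series, first, only, none or still open, it means among the compounds named here.

In an ADME assay on cells (Fibroblast, Gallus gallus) for cytotoxicity, read by CCK-8 assay, with a stated time of 48 h (a higher number here means that more compound is tolerated, a lower number that less compound is tolerated), compound 1 `CCc1ccc(CN[C@H]2CC(C(=O)O)=C[C@@H](OC(CC)CC)[C@@H]2NC(C)=O)cc1` gives > 200000 nM, which is a limit and not a number. In this assay compound 2 `CCC(CC)O[C@@H]1C=C(C(=O)O)C[C@H](NCc2ccc(SCC(C)C)cc2)[C@H]1NC(C)=O` gives > 200000 nM, which is also a limit. Neither compound therefore has an exact value yet.

Compound 3 `CCC(CC)O[C@@H]1C=C(C(=O)O)C[C@H](NCc2ccc(SC(C)CC)cc2)[C@H]1NC(C)=O` differs from compound 2 in one group: sec-butyl in place of isobutyl on a sulfur. The two have the same atoms, joined differently, and the change sits on a sulfur whose other neighbour is an aromatic carbon.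

Among the measured compounds shown here, the only measured step that bears on this is a step that the two limits leave unreadable from compound 1 to compound 2. That step put the isobutylsulfanyl group in place of ethyl, and it offers no size to carry over to the new change.

Given that compound 2 stands at the limit of > 200000 nM in this assay, at which 2 of the 2 values shown sit, no step beyond the usual scatter is expected, and the estimated step is a step that the limit leaves unreadable from compound 2 to compound 3. The most likely report in this assay is another limit. For compound 3 the estimated half-maximal cytotoxic concentration is 250000 nM, with an expected range from 120000 nM to 500000 nM.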

Compound 3, half-maximal cytotoxic concentration: > 200000 nM
Compound 3 was reported as a limit; the forecaster's own chance of this, stated with the estimate: 85%; the middle value lies beyond the limit too.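

Among the compounds shown here, compound 1, compound 2 and compound 3 are each reported only as a limit in this assay, so no step among them can be read. The compounds shown leave open where the exact value of each one lies, and so whether sec-butyl and isobutyl on a sulfur differ at all here.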